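This account rests on a few compounds, and the source may have more. Where it says the series, first, only, none or still open, it means among the compounds named here.

Among the measured compounds shown here, compound 1 `C=Cc1cccc(C(=O)NCN2CCC(c3cccc[n+]3[O-])CC2)c1` is one of three compounds measured in a functional assay on HEK293 cells for agonist activity at D(4) dopamine receptor (Homo sapiens), read by FLIPR (on this read-out higher numbers stand for an effect only at larger amounts of compound and lower numbers for an effect already at smaller amounts), where compound 1 gives 68 nM. Among these three numbers it holds the second highest place. Compound 2 `Cc1cccc(NC(=O)CN2CCC(c3cccc(O)c3)CC2)c1` gives 8 nM in this assay, and compound 3 `CCOc1cccc(C(=O)NCN2CCC(c3cccc[n+]3[O-])CC2)c1` gives 324 nM. Compound 3 differs from compound 1 in a single place, and that step is a 4.8-fold higher number from compound 1 to compound 3 (0.68 log units; beyond the scatter), a modest change that goes toward weaker activity.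

Compound 4 `Cc1ccc(C(=O)NCN2CCC(c3cccc[n+]3[O-])CC2)cc1C` has not yet been measured in this assay. The change from compound 1 to compound 4 is 3,4-dimethylphenyl in place of 3-vinylphenyl on a carbonyl carbon. For the measured compounds named here, no measured step swaps one group for another on exactly this carbonyl carbon in the same way; the only comparison on that part of the shared core is the one from compound 1 to compound 3, which moved the number upward by a modest amount. On that slender basis the expected outcome for compound 4 is a small shift in the same direction or no change beyond the scatter, giving a 1.6-fold higher number from compound 1 to compound 4 (0.21 log units; within the scatter). Compound 4 is therefore estimated at 110 nM, with a range from 35 nM to 350 nM.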

Compound 4, half-maximal effective concentration: 38 nM
Beside the measured number, compound 4's estimate is 2.9-fold (0.46 log units) above it; the range from low to high includes it.
By their numbers in this assay, from the lowest: compound 2; then compounds 4 and 1 (each within the scatter of the next); then compound 3.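

Exchanging 3-vinylphenyl for 3,4-dimethylphenyl on the carbonyl carbon is a 1.8-fold lower number from compound 1 to compound 4 (0.25 log units; within the scatter) in this assay, so the two compounds cannot be told apart on this read-out. The double bond outside the aromatic ring leaves with the vinyl group, and compound 4 keeps a number in the same range, so activity at this level does not require that double bond. Among the compounds shown here, the earlier step, a 4.8-fold higher number from compound 1 to compound 3 (0.68 log units; beyond the scatter), was the only change seen here on this part of compound 1, and the new result shows that a change here need not carry the number beyond the scatter. Nothing available explains either step.

An amine or a carboxylic acid on this aromatic ring remains untested among the compounds shown, so they cannot tell whether such groups would be tolerated as the two methyl groups are.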